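Switching the aryl group on the piperazine of compound 2

The source may report more compounds than this note shows. Statements on the series, on what has been measured and on what is new or still open speak of the compounds shown alone.

Measured compounds:
Compound 1 `C=C(C)c1cccc(N2CCN(C(=O)c3oc(C)nc3-c3ccccc3F)CC2)c1`: "not active" (no number reported)
Compound 2 `Cc1nc(-c2ccccc2)c(C(=O)N2CCN(c3c(C)cccc3C)CC2)o1`: 146 nM
Compound 3 `CCCc1nc(-c2ccc(OC)cc2)c(C(=O)N2CCN(c3cccc(Cl)c3)CC2)o1`: "not active" (no number reported)

In a functional assay on HL-60 cells (Homo sapiens) for inhibition, read by MTT assay, with a stated time of 72 h (on this read-out higher numbers stand for weaker inhibition and lower numbers for stronger inhibition), compound 2 gives 146 nM. For the measured compounds named here, it is the only compound of the three with a reported number. In this assay, going by the values given here, compound 1 gives "not active" (no number reported), and in this assay compound 3 gives "not active" (no number reported), so no step between measured compounds can be drawn, and nothing says how far the activity of compound 2 depends on the group on the ring nitrogen.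

Compound 4 `CC(=O)c1ccc(N2CCN(C(=O)c3oc(C)nc3-c3ccccc3)CC2)cc1` has not yet been measured. It differs from compound 2 in one place: 4-acetylphenyl in place of 2,6-dimethylphenyl on an amine nitrogen in a ring. The core with a methyl group and an unsubstituted phenyl on the oxazole is kept from compound 2.

Because compound 1, carrying a different aryl group on the ring nitrogen, gave "not active" (no number reported) and compound 3, carrying yet another, gave "not active" (no number reported), the writer expects a weakening step from compound 2 to compound 4 in this assay, of the size a 10-fold higher number from compound 2 to compound 4 (1.01 log units; beyond the scatter), with a real chance that no number is reported. Compound 4 is estimated at 1500 nM, within a range from 250 nM to 10000 nM.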

Compound 4, half-maximal inhibitory concentration: "not active" (no number reported)
Nothing numeric was reported for compound 4; no gap can be computed for the estimate.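

In this assay, for the compounds shown here, compound 4 gives "not active" (no number reported) and compound 2 gives 146 nM, so no step between them can be read, and no available evidence bears on this result. The compounds shown leave open whether any aryl group other than 2,6-dimethylphenyl on the ring nitrogen gives a reported number.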